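Aryl ketone exchange on the shared core: antiproliferative notes

The compounds below may be only part of what the source reports. "The series", "measured", "known", "first", "only" and "open" are said of these compounds alone.

Measured so far:
- compound 1, `COc1ccc(-c2cc3ccccc3nc2C=O)cc1`, gives > 10000 nM in a functional assay on NCI-H460 cells (Homo sapiens) for antiproliferative activity, read by XTT assay, with a stated time of 72 h; on this read-out lower numbers stand for stronger inhibition and higher numbers for weaker inhibition; this reading is a limit of the assay, not a number.
- compound 2, `COc1ccc(-c2cc3ccccc3nc2/C=C/C(=O)c2ccc(F)cc2)cc1`, gives 6990 nM in this assay.
- compound 3, `COc1ccc(-c2cc3ccccc3nc2/C=C/C(=O)c2ccc(OC)cc2OC)cc1`, gives 7040 nM in this assay.

Compound 3 holds the highest of the two numbers in this assay, with compound 2 nearest, and the two lie within the scatter of each other. Compound 1 sits at the limit of > 10000 nM in this assay, at which 1 of the 3 values shown sits. No ordering among the three can be read from this.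

Compound 4, `COc1ccc(-c2cc3ccccc3nc2/C=C/C(=O)c2ccc(N)cc2)cc1`, differs from compound 3 by 4-aminophenyl in place of 2,4-dimethoxyphenyl on a carbonyl carbon. For the measured compounds named here, the only measured step at this place is a 1.0-fold higher number from compound 2 to compound 3 (0.00 log units; within the scatter), which swapped one aryl group on the carbonyl carbon for another and left the number where it was. Going by the values given here, no measured step brings in an aminophenyl group or a hydrogen-bond donor at this place, so the expectation rests on that single step alone and carries the width that implies. The step expected from this change is a 1.0-fold lower number from compound 3 to compound 4 (0.00 log units; within the scatter), that is, none beyond the scatter. Compound 4 is accordingly estimated at 7000 nM in this assay, with a range expected from 2500 nM to 20000 nM.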

Compound 4, half-maximal inhibitory concentration: 7400 nM
Compound 4: middle estimate off by 1.1-fold (0.02 log units), on the low side, within the range that was stated.
By their numbers in this assay, from the lowest: compounds 2, 3 and 4 (each within the scatter of the next). At a limit, above all of these: compound 1.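

The aryl group on the carbonyl carbon now has three versions in this assay, and the exchange of 2,4-dimethoxyphenyl for 4-aminophenyl gives a 1.1-fold higher number from compound 3 to compound 4 (0.02 log units; within the scatter). The direct comparison of the two para-free named groups is no different: amino in place of fluoro on an aromatic carbon gives a 1.1-fold higher number from compound 2 to compound 4 (0.02 log units; within the scatter). Compounds 2, 3 and 4 therefore lie within the scatter of one another, and this now holds for an aryl group with a hydrogen-bond donor as well as for two without one, and for a group with fewer heavy atoms than 2,4-dimethoxyphenyl; the measurements shown offer no explanation for this flat reading.

The compounds shown leave open whether anything on the carbonyl carbon can move the number beyond the scatter, for example a cyclohexyl group in place of the aryl ring, or a phenyl ring bearing a carboxylic acid or a dimethylamino group. Also open, as far as these compounds go, is what the methoxy group contributes, as all four compounds carry it, and a hydroxy group or a chlorine there would speak to that.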